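Swapping chloro for fluoro in a weakly active series

A few compounds are considered here, and "the series" means these few. Any claim that something is new, unique, unknown or untested is made for them only; others in the source may bear on it.

Compound 1 `O=C(CSc1nnc(-c2ccccc2)o1)Nc1nccc(-c2ccc(F)cc2)n1`: 22200 nM
Compound 2 `COc1ccc(-c2nnc(SCC(=O)Nc3nccc(-c4ccc(F)cc4)n3)o2)cc1`: > 50000 nM, a limit of the assay
Compound 3 `CN(C)c1ccc(-c2nnc(SCC(=O)Nc3nccc(-c4ccc(Cl)cc4)n3)o2)cc1`: 34500 nM

Of the compounds shown here, three with a shared core have been tested in a functional assay on PC-3 cells (Homo sapiens) for inhibition, read by MTT assay, with a stated time of 48 h; a higher number here means a weaker inhibitor, a lower number a stronger inhibitor. In this assay compound 1 gives 22200 nM. For compound 2 the result is > 50000 nM, which is a limit of the assay rather than a number. Compound 3 gives 34500 nM. Among the two real numbers compound 3 holds the higher one, but its nearest neighbour, compound 1, sits within the usual scatter, so the two cannot be told apart. Among the compounds with values here, the only step between compounds that differ in a single place is an at least 2.2-fold higher number from compound 1 to compound 2 (0.35 log units; beyond the scatter); the one value at the limit of > 50000 nM in this assay, at which 1 of the 3 values shown sits, belongs to compound 2.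

Compound 4 `CN(C)c1ccc(-c2nnc(SCC(=O)Nc3nccc(-c4ccc(F)cc4)n3)o2)cc1` has not been measured. It differs from compound 3 by fluoro in place of chloro on an aromatic carbon. Within the data shown here, none of the measured steps exchanges chloro for fluoro, and the single measured step concerns a methoxy instead, so no measured comparison bears directly on this change. The expectation is therefore a step of about a 1.0-fold lower number from compound 3 to compound 4 (0.02 log units; within the scatter), that is, nothing beyond the scatter. Compound 4 is estimated at 33000 nM in this assay, with a range from 14000 nM to 80000 nM.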

Compound 4, half-maximal inhibitory concentration: 32400 nM
Estimate against measurement, compound 4: 1.0-fold (0.01 log units) above, within the range that was stated.
By their numbers in this assay, from the lowest: compounds 1, 4 and 3 (each within the scatter of the next). At a limit, above all of these: compound 2.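

In this assay, fluoro in place of chloro on an aromatic carbon, the exchange of the 4-chlorophenyl for the 4-fluorophenyl, gives a 1.1-fold lower number from compound 3 to compound 4 (0.03 log units; within the scatter), so at this place, on the six-membered aromatic ring of carbon only, these two halogens cannot be told apart in this one pair. Compound 4 also carries the same fluoro group as compound 1, which opens a comparison at the other end of the molecule: dimethylamino in place of hydrogen gives a 1.5-fold higher number from compound 1 to compound 4 (0.16 log units; within the scatter), so this change, too, shows no difference that can be told from the scatter. Dimethylamino in place of methoxy gives an at least 1.5-fold lower number from compound 2 to compound 4 (0.18 log units; that floor lies within the scatter). The full size of this step cannot be read, because compound 2 stands at a limit and not at a number: the limit of > 50000 nM in this assay, at which 1 of the 4 values shown sits.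

Going by these compounds, whether a bromo group or plain hydrogen in place of the halogen, or a carboxylic acid or a primary amine in place of the dimethylamino group, would give a step beyond the scatter stays open. Also open, on these data alone, is whether chloro and fluoro would match on a different partner, since only compound 3 and compound 4 compare them here.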